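The source may report more compounds than this note shows. Statements on the series, on what has been measured and on what is new or still open speak of the compounds shown alone.

In a functional assay on LOX IMVI cells (Homo sapiens) for cytotoxicity, read by sulforhodamine B assay, with a stated time of 24 h (on this read-out lower numbers stand for stronger inhibition of growth and higher numbers for weaker inhibition of growth), compound 2 `O=C(/C=C/c1cc2ccccc2[nH]c1=O)c1ccc(O)cc1` gives 12700 nM, the highest of the two numbers measured. Its nearest neighbour is compound 1 `COc1ccc(C(=O)/C=C/c2cc3ccccc3[nH]c2=O)cc1`, which in this assay gives 5540 nM; the step of a 2.3-fold higher number from compound 1 to compound 2 (0.36 log units; beyond the scatter) is the only one recorded. Compound 3 `O=C(/C=C/c1cc2ccccc2[nH]c1=O)c1ccc(Cl)cc1` differs from compound 2 by chloro in place of hydroxy on an aromatic carbon. Within the data shown here, the one known step, from compound 1 to compound 2, runs in the opposite direction and is modest, so compound 3 is expected to give a number like that of compound 1, a step of a 2.5-fold lower number from compound 2 to compound 3 (0.40 log units; beyond the scatter). Compound 3 is therefore estimated at 5000 nM, between 1500 nM and 15000 nM.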

Compound 3, concentration for total growth inhibition: 22100 nM
Compound 3: the middle estimate sits 4.4-fold (0.65 log units) below what was measured, and the stated range ends below it.
By their numbers in this assay, from the lowest: compound 1; then compounds 2 and 3 (each within the scatter of the next).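

At this position, para to a large group, chloro and hydroxy do not separate, a 1.7-fold higher number from compound 2 to compound 3 (0.24 log units; within the scatter), so only the methoxy of compound 1 stands apart among the three groups, a 4.0-fold higher number from compound 1 to compound 3 (0.60 log units; beyond the scatter). Compound 3 thus shows that replacing hydroxy does not by itself bring the number down to that of compound 1. No evidence given here bears on this result. The compounds shown leave open whether ethoxy, a longer chain on the same oxygen, would follow methoxy, and where an amine or a carboxylic acid would fall at this position.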